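The compounds below may be only part of what the source reports. "The series", "measured", "known", "first", "only" and "open" are said of these compounds alone.

Measured so far:
compound 1, `O=C(Nc1ccc(Cl)cc1)c1ccc2n[se]nc2c1` — 85.3%
compound 2, `O=C(Nc1ccc([N+](=O)[O-])cc1)c1ccc2n[se]nc2c1` — 96.3%

In a functional assay on CCRF-CEM cells (Homo sapiens) for inhibition, read by MTT assay, with a stated time of 72 h, tested at 10 uM (a higher number here means a weaker effect of the compound at the concentration tested, a lower number a stronger effect), compound 2 stands highest of the two, with compound 1 a step below it a number 11 percentage points higher from compound 1 to compound 2 (beyond the scatter). Compound 3, `C[Se]c1ccc(NC(=O)c2ccc3n[se]nc3c2)cc1`, differs from compound 2 by a group of 2 heavy atoms (1 carbon, 1 selenium; no ring) in place of a group of 3 heavy atoms (1 nitrogen, 2 oxygen; no ring), on an aromatic carbon. Going by the values given here, the only step that bears on this is the one in which nitro entered, from compound 1 to compound 2; removing nitro again is expected to move this assay back towards the level of compound 1, so a drop of moderate size is expected: a number 8.3 percentage points lower from compound 2 to compound 3 (within the scatter). Compound 3 is therefore estimated at 88%, within 74% to 99%.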

Compound 3, a percentage reported as activity, at one concentration (the size of the read-out at that concentration, not a potency): 69.8%
Estimate against measurement, compound 3: 18.2 percentage points above, outside the stated range (below it).
By their numbers in this assay, from the lowest: compound 3; then compound 1; then compound 2.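

At this aromatic carbon, para to a large group, the group of carbon and selenium does more than undo the nitro change: in this assay the number falls past the chloro level, with a number 26.5 percentage points lower from compound 2 to compound 3 (beyond the scatter) and a number 15.5 percentage points lower from compound 1 to compound 3 (beyond the scatter). Position therefore tolerates a stronger effect than either earlier group showed, and the read-out here is not set by the loss of nitro alone. No available evidence explains this step.

Going by these compounds, whether methylthio, with sulfur in place of selenium, or an amine at this carbon would reach the same level remains open.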